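This account rests on a few compounds, and the source may have more. Where it says the series, first, only, none or still open, it means among the compounds named here.

Measured so far in a functional assay on RS4-11 cells (Homo sapiens) for inhibition, read by CCK-8 assay, with a stated time of 48 h, tested at 20 uM; on this read-out lower numbers stand for less inhibition of growth and higher numbers for more inhibition of growth at the one concentration tested:
- compound 1 `Cc1ccc(S(=O)(=O)Oc2ccccc2/C=C(\C#N)C(=O)Nc2nnc(Cc3ccc(F)cc3)s2)cc1`: 72%
- compound 2 `COc1ccc(S(=O)(=O)Oc2ccccc2/C=C(\C#N)C(=O)Nc2nnc(Cc3ccc(F)cc3)s2)cc1`: 76%

In this assay compound 2 stands at 76%. Going by the values given here, with only two numbers available, it lies within the scatter of compound 1, so the two cannot be ranked.

The next compound is compound 3 `N#C/C(=C\c1ccccc1OS(=O)(=O)c1ccc([N+](=O)[O-])cc1)C(=O)Nc1nnc(Cc2ccc(F)cc2)s1`, which has nitro in place of methoxy on an aromatic carbon, para to a large group: nitro in place of methoxy on an aromatic carbon. The rest of the structure is shared with compound 2.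

Among the compounds with values here, only one measured step bears on this change: a number 4 percentage points higher from compound 1 to compound 2 (within the scatter). It is a swap of methyl for methoxy on an aromatic carbon and stays within the scatter. Within the data shown here, that is thin evidence, since it is a single step and no nitro compound has yet been measured. It gives no reason to expect a shift in either direction, so no step beyond the scatter is expected, although the uncertainty is wide.

The expected change is a number 4 percentage points lower from compound 2 to compound 3 (within the scatter).

The estimate for compound 3 is 72%, with an expected range from 58% to 86%.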

Compound 3, percent growth inhibition at one concentration: 55%
Compound 3: middle estimate off by 17 percentage points, on the high side, outside the stated range (below it).
By their numbers in this assay, from the lowest: compound 3; then compounds 1 and 2 (each within the scatter of the next).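

In this assay, the place on the aromatic carbon para to a large group proves sensitive to what it carries: nitro in place of methoxy gives a number 21 percentage points lower from compound 2 to compound 3 (beyond the scatter), and nitro in place of methyl gives a number 17 percentage points lower from compound 1 to compound 3 (beyond the scatter), whereas methoxy in place of methyl gave only a number 4 percentage points higher from compound 1 to compound 2 (within the scatter) at the same place. Going by these compounds alone, the compound with the (4-nitrophenyl)sulfonyl group therefore separates from both neighbours, while the methyl and methoxy compounds still cannot be ranked against each other, so the swap to nitro is the only kind of change here that reaches beyond the scatter. No measurement at hand accounts for this difference, so its cause stays unassigned.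

On these data alone, whether the lower number is specific to nitro or recurs with other groups at this place, such as an amine, a carboxylic acid or a chlorine atom, remains open. Also open, as far as these compounds go, is whether the same swap gives a similar step when the rest of the structure changes, since all three compounds share one core and one read-out at a single concentration.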